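The compounds below may be only part of what the source reports. "The series", "measured", "known", "first", "only" and "open" are said of these compounds alone.

Measured compounds:
- compound 1, `CC(C)OC(=O)N1CCC(Oc2ncnc3c2CCN3c2ccc(-c3cccn3C)cc2F)CC1`, in a functional assay on CHO-K1 cells for agonist activity at Glucose-dependent insulinotropic receptor (Homo sapiens), read by a luciferase reporter, with a stated time of 5 h (on this read-out lower numbers stand for an effect already at smaller amounts and higher numbers for an effect only at larger amounts of compound), compound 1 gives 158 nM
- compound 2, `CCCOC(=O)N1CCC(Oc2ncnc3c2CCN3c2ccc(S(C)(=O)=O)cc2F)CC1`, in this assay compound 2 gives 79.4 nM

The two measured values lie within the usual scatter of each other, so compound 2 does not stand apart from compound 1 on this assay; its number is simply the one at the lower end of a pair that cannot be told apart with confidence. For the measured compounds named here, no single-point step between the two measured compounds is available, as they differ in more than one place.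

Compound 3, `COCCOC(=O)N1CCC(Oc2ncnc3c2CCN3c2ccc(S(C)(=O)=O)cc2F)CC1`, is a close relative of compound 2. Going by the values given here, the only change is methoxy in place of methyl on a saturated chain carbon, two bonds along the chain from an oxygen next to a carbonyl group. The carbamate chain thus goes from propyl to 2-methoxyethyl, with the rest of compound 2 kept intact. Among the compounds with values here, with no comparable step measured, there is no basis for expecting a shift beyond the scatter in either direction; the step is expected to be small.

Compound 3 is therefore estimated to give 85 nM in this assay, with a range from 35 nM to 210 nM, which corresponds to an expected 1.1-fold higher number from compound 2 to compound 3 (0.03 log units; within the scatter).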

Compound 3, half-maximal effective concentration: 316 nM
Beside the measured number, compound 3's estimate is 3.7-fold (0.57 log units) below it; the measured number lies above the stated range.
By their numbers in this assay, from the lowest: compounds 2, 1 and 3 (each within the scatter of the next, the first and the last beyond it).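

In this assay, for the compounds shown here, the carbamate chain proves to be a place that responds: methoxy in place of methyl on a saturated chain carbon, two bonds along the chain from an oxygen next to a carbonyl group, gives a 4.0-fold higher number from compound 2 to compound 3 (0.60 log units; beyond the scatter), the only step here that isolates a single change. The rest of the structure is the same in both compounds, so this step belongs to the move from propyl to 2-methoxyethyl, something the earlier pair, which differs in more than one place, could not show. Nothing measured here explains why the number rises with this change.

Going by these compounds, it remains open whether the rise is tied to the ether oxygen or would also appear with other groups at this place, such as a hydroxyl, a dimethylamino group or a longer chain such as butyl. On these data alone, it is also open whether the same move from propyl to 2-methoxyethyl would give a step of similar size with the rest of compound 1 in place of the rest of compound 2.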